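The source may report more compounds than this note shows. Statements on the series, on what has been measured and on what is new or still open speak of the compounds shown alone.

Measured so far:
compound 1 `C#CCNC1CCc2c(SCc3cccc(C(F)(F)F)c3)cccc21`, 4.7 nM in an assay on isolated protein for inhibition of Amine oxidase [flavin-containing] B (Homo sapiens); a higher number here means a weaker inhibitor, a lower number a stronger inhibitor
compound 2 `C#CCNC1CCc2c(SCCc3ccc(OC)cc3)cccc21`, 62000 nM in this assay
compound 3 `C#CCNC1CCc2c(SCc3cccc(OC)c3)cccc21`, 3190 nM in this assay

Compound 2 gives the highest number of the three, and the difference between its core and that of compound 3 is not broken down here. For the measured compounds named here, the one counted change, (trifluoromethyl in place of methoxy on an aromatic carbon), gave a 680-fold lower number from compound 3 to compound 1 (2.83 log units; beyond the scatter). The unmeasured compound 4 `C#CCNC1CCc2c(SCCc3ccc(C(F)(F)F)cc3)cccc21` carries the change (trifluoromethyl in place of methoxy on an aromatic carbon). The place lines differ: in compound 1 the trifluoromethyl sits meta to a large group, in compound 4 para to a large group, so this is the same kind of change, not the same one. Going by the values given here, the step from compound 2 to compound 4 in this assay is expected to be a large drop, close in size to a 680-fold lower number from compound 3 to compound 1 (2.83 log units; beyond the scatter) though with wide uncertainty because only that one step is known, giving an expected 250-fold lower number from compound 2 to compound 4 (2.39 log units; beyond the scatter). Compound 4 is therefore estimated at 250 nM, expected to fall between 40 nM and 2500 nM.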

Compound 4, half-maximal inhibitory concentration: 16100 nM
For compound 4 the middle estimate is 64-fold (1.81 log units) below the measured one; measured number outside the range, above it.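

In this assay, putting trifluoromethyl in place of methoxy on an aromatic carbon gives a 3.9-fold lower number from compound 2 to compound 4 (0.59 log units; beyond the scatter), a modest step. The number falls on both cores, so the direction of the change carries over, but its size does not: the same change on two cores in this assay, a 680-fold lower number (2.83 log units; beyond the scatter) from compound 3 to compound 1 and a 3.9-fold lower number (0.59 log units; beyond the scatter) from compound 2 to compound 4, 180-fold (2.25 log units) apart, beyond the scatter of two such steps Two pairs cannot show what sets the size of the step, as they differ both in the core and in where the group sits on the aromatic ring, and the data do not separate these two differences.

The compounds shown leave open whether the step would stay small on the core of compound 2 with trifluoromethyl at another place on that ring, and whether it would stay large on the core of compound 1 with the group moved. Also open, on these data alone, is whether a chlorine atom or a nitrile in the same place would follow trifluoromethyl on either core.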